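The source may hold more compounds than are shown below. What is called first, only, known or untested is meant among the compounds shown, and "the series" means these compounds.

Measured compounds:
compound 1, `Cc1ccc2nc(NCCCCOc3cc(O)c4c(=O)cc(-c5ccccc5)oc4c3)sc2c1`: 28.1 ug/mL
compound 2, `O=c1cc(-c2ccccc2)oc2cc(OCCCCNc3nc4ccc(I)cc4s3)cc(O)c12`: 25.4 ug/mL
compound 3, `O=c1cc(-c2ccccc2)oc2cc(OCCCCNc3nc4c(F)cc(F)cc4s3)cc(O)c12`: 15.1 ug/mL

In a physicochemical assay, read by spectrophotometry, with a stated time of 25 min (a higher number here means a weaker inhibitor, a lower number a stronger inhibitor), compound 3 holds the lowest of the three numbers, yet its separation from the others is small: the step of a 1.9-fold lower number from compound 1 to compound 3 (0.27 log units; within the scatter) and the step of a 1.7-fold lower number from compound 2 to compound 3 (0.23 log units; within the scatter) both sit within the scatter, as does a 1.1-fold lower number from compound 1 to compound 2 (0.04 log units; within the scatter). Nothing here therefore ranks the three compounds against each other.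

Compound 4, `O=C(O)c1ccc2nc(NCCCCOc3cc(O)c4c(=O)cc(-c5ccccc5)oc4c3)sc2c1`, is not yet measured. It differs from compound 3 by 6-carboxy-1,3-benzothiazol-2-yl in place of 4,6-difluoro-1,3-benzothiazol-2-yl on an amine nitrogen. Going by the values given here, none of the measured steps brings in a carboxy group or any hydrogen-bond donor on this ring; the three steps only exchange methyl, iodo and difluoro substitution, and all of them stay within the scatter. The closest guide is that varying this substituent pattern has so far moved the number little. He therefore expects a step of a 1.2-fold higher number from compound 3 to compound 4 (0.08 log units; within the scatter) that lies within the scatter, with the wider range reflecting that this substituent type is new. Compound 4 is estimated at 18 ug/mL, between 8 ug/mL and 40 ug/mL.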

Compound 4, half-maximal inhibitory concentration: 21.7 ug/mL
The estimate for compound 4 lay 1.2-fold (0.08 log units) below the measured number, within the range that was stated.
By their numbers in this assay, from the lowest: compounds 3, 4, 2 and 1 (each within the scatter of the next).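

In this assay, going by these compounds alone, the carboxy group is the first substituent on this ring to bring a hydrogen-bond donor, and it still leaves the number within the scatter of all three earlier compounds, with a 1.4-fold higher number from compound 3 to compound 4 (0.16 log units; within the scatter) and a 1.2-fold lower number from compound 2 to compound 4 (0.07 log units; within the scatter) and a 1.3-fold lower number from compound 1 to compound 4 (0.11 log units; within the scatter) as the three steps. The flat picture seen with methyl, iodo and difluoro substitution therefore extends to a group of a different kind on the 1,3-benzothiazol-2-yl ring, and the four compounds cannot be ranked by this substituent. No measurement is available that bears on this result.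

From the compounds shown here alone, whether an amine or a primary amide on this ring would give a step beyond the scatter stays open. So does whether a shorter or longer chain on the amine nitrogen, or a ring without any substituent, would move the number in this assay.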